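The source may hold more compounds than are shown below. What is called first, only, known or untested is meant among the compounds shown, and "the series" means these compounds.

Compound 1 `COc1ccc2[nH]c(C(=O)N3CC(=O)N(Cc4ccccc4)[C@@H](CN4CCC(C)CC4)C3)cc2c1` is the starting point. In an ADME assay on Vero cells (Chlorocebus sabaeus) for cytotoxicity, with a stated time of 7 days (a higher number here means that more compound is tolerated, a lower number that less compound is tolerated), compound 1 gives > 30000 nM, which is a limit of the assay rather than a measured number; (the limit of > 30000 nM in this assay, at which 1 of the 3 values shown sits). Two other compounds from the same series have numbers: compound 2 `O=C(c1cc2cc(C3CC3)ccc2[nH]1)N1CC(=O)N(Cc2ccccc2)[C@@H](CN2CCN(Cc3ccccc3)CC2)C1` gives 5500 nM in this assay, and compound 3 `COc1ccc2[nH]c(C(=O)N3CC(=O)N(Cc4ccc[nH]4)[C@@H](Cc4ccccc4)C3)cc2c1` gives 15200 nM there. Compound 4 `COc1ccc2[nH]c(C(=O)N3CC(=O)N(Cc4ccccc4)[C@@H](CN4CCn5cccc5C4)C3)cc2c1` has not yet been tested. It differs from compound 1 in one place: a group of 9 heavy atoms (7 carbon, 2 nitrogen; one five-membered aromatic ring with 1 hetero atom, one six-membered non-aromatic ring with 2 hetero atoms) in place of a group of 7 heavy atoms (6 carbon, 1 nitrogen; one six-membered non-aromatic ring with 1 hetero atom), on a saturated chain carbon bound to a saturated ring carbon. Among the compounds with values here, no pair of measured compounds shows the effect of this change, so the expected step from compound 1 to compound 4 is small, an at least 1.2-fold lower number from compound 1 to compound 4 (0.07 log units; that floor lies within the scatter), within the usual scatter. Compound 4 is therefore expected to give about 25000 nM in this assay, between 8000 nM and 60000 nM.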

Compound 4, half-maximal cytotoxic concentration: > 100000 nM
Compound 4: no number, only a limit; the forecaster's own chance of this, stated with the estimate: 50%; middle value at least 4.0-fold (0.60 log units) away from the limit.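

Within the data shown here, compound 1 and compound 4 both give only limits of the assay, not numbers, and no step between them can be read. The compounds shown leave open whether replacing the 4-methylpiperidin-1-yl group changes the half-maximal cytotoxic concentration at all.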